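Swapping carbamoyl for an oxadiazole in a stable compound

The source may report more compounds than this note shows. Statements on the series, on what has been measured and on what is new or still open speak of the compounds shown alone.

Compound 1 `CC(C)[C@H]1C(O)=C(C2=NS(=O)(=O)c3c(OCC(N)=O)cccc32)C(=O)N1Cc1ccccc1` - > 1 h
Compound 2 `CC(C)(C)[C@H]1C(O)=C(C2=NS(=O)(=O)c3c(OCC(N)=O)cccc32)C(=O)N1Cc1ccc(F)c(Cl)c1` - > 1 h

In an in vitro ADME assay on microsomes from liver (Homo sapiens) for metabolic stability (on this read-out higher numbers stand for a longer-lived compound and lower numbers for a shorter-lived compound), compound 2 gives > 1 h, which is a limit of the assay and not a number. Compound 2 therefore stands at the limit of > 1 h in this assay, at which 2 of the 2 values shown sit.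

Compound 3 `CC(C)(C)[C@H]1C(O)=C(C2=NS(=O)(=O)c3c(OCc4ncon4)cccc32)C(=O)N1Cc1ccc(F)c(Cl)c1` is still unmeasured. The change 1,2,4-oxadiazol-3-yl in place of carbamoyl on a saturated chain carbon bound to an oxygen on an aromatic ring puts 1,2,4-oxadiazol-3-yl in place of carbamoyl on a saturated chain carbon bound to an oxygen on an aromatic ring. Among the compounds with values here, no measured pair of compounds shows this change, so no shift beyond the scatter is expected in this assay. The expected size of the change is a step that the limit leaves unreadable from compound 2 to compound 3. For compound 3 the estimated half-life is 1.5 h, with an expected range of 0.7 h to 3 h.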

Compound 3, half-life: > 1 h
Compound 3: only a limit was reported; the forecaster's own chance of this, stated with the estimate: 65%; the middle value lies beyond the limit too.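

No step from compound 2 to compound 3 can be read in this assay, because both values are limits of the assay and not numbers: the limit of > 1 h in this assay, at which 3 of the 3 values shown sit.

The compounds shown leave open how long each one actually lasts, and whether 1,2,4-oxadiazol-3-yl in place of carbamoyl changes the half-life at all.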